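Swapping the aryl group on the piperidine of compound 2

The source may report more compounds than this note shows. Statements on the series, on what has been measured and on what is new or still open speak of the compounds shown alone.

Measured so far:
Compound 1, `CCCn1c(CN2CCN(c3ncc(Cl)cn3)CC2)nc2ccccc21`: 794 nM
Compound 2, `Cn1c(CN2CCC(c3ccc(Cl)cc3)CC2)nc2ccccc21`: 79.4 nM
Compound 3, `COc1ccc2c(c1)nc(CN1CCN(c3nc(Cl)ccc3C(F)(F)F)CC1)n2C`: 251 nM

The three compounds were all tested in an assay on CHO cells with metabotropic glutamate receptor 2 (Homo sapiens) as the target, read by FLIPR; a lower number here means that less compound is needed, a higher number that more compound is needed for the effect. Compound 2 stands lowest of the three numbers. Compound 3 comes nearest to it, with a number beyond the scatter of repeat measurements, and compound 1 lies furthest away. Compounds 1 and 3 differ from compound 2 in more than one place, so their values show only where they fall, not what any single change does.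

The next compound, compound 4, `Cn1c(CN2CCC(c3ccccc3F)CC2)nc2ccccc21`, has not yet been measured. It differs from compound 2 in one place: 2-fluorophenyl in place of 4-chlorophenyl on a saturated ring carbon. Within the data shown here, no single-change step among the measured compounds gives a direct guide to this swap. Compound 4 is expected to need somewhat more compound than compound 2, with a step from compound 2 to compound 4 of a 2.5-fold higher number from compound 2 to compound 4 (0.40 log units; beyond the scatter) in this assay, a moderate weakening that may or may not exceed the scatter. The value of compound 4 is estimated at 200 nM, within a range of 60 nM to 630 nM.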

Compound 4, half-maximal effective concentration: 126 nM
Beside the measured number, compound 4's estimate is 1.6-fold (0.20 log units) above it; the measured number falls inside the stated range.
By their numbers in this assay, from the lowest: compounds 2, 4 and 3 (each within the scatter of the next, the first and the last beyond it); then compound 1.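

In this assay, among these compounds, 2-fluorophenyl in place of 4-chlorophenyl on the saturated ring carbon gives a 1.6-fold higher number from compound 2 to compound 4 (0.20 log units; within the scatter), the first single-change step in this set, and it shows that the assay does not separate these two aryl groups at this position. The halogen and its place on the phenyl ring change together in this swap, so the step says nothing about either change alone. Nothing measured here explains why the number stays within the scatter across this swap.

What the compounds shown leave open is how 2-chlorophenyl or 4-fluorophenyl would read, as either could separate the halogen from its place. Going by these compounds, it also remains open whether unsubstituted phenyl, or a phenyl carrying an amine or a carboxylic acid, would keep the number in this range.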